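The compounds below may be only part of what the source reports. "The series", "measured", "known", "first", "only" and "open" are said of these compounds alone.

Measured compounds:
- compound 1, `Nc1cc(N)c2nc(-c3ccccc3)c(Oc3ccc(Cl)c(Cl)c3)nc2c1`: 64600 nM
- compound 2, `CCOC(=O)[C@H](CCC(=O)O)NC(=O)c1ccc(Sc2nc3cc(N)cc(N)c3nc2-c2ccccc2)cc1`: 33900 nM
- compound 3, `CCOC(=O)[C@H](CCC(=O)O)NC(=O)c1ccc(Oc2nc3cc(N)cc(N)c3nc2-c2ccccc2)cc1`: 30200 nM

All three share the same core and were measured in a functional assay on SK-MEL-28 cells (Homo sapiens) for inhibition, read by sulforhodamine B assay, with a stated time of 48 h; a higher number here means a weaker inhibitor of growth, a lower number a stronger inhibitor of growth. Compound 1 gives the highest of the three numbers; the value of compound 2 lies within the scatter of it, so no order between compound 1 and compound 2 can be read from these two values, while compound 3 sits beyond the scatter on the lower side.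

Compound 4, `Nc1cc(N)c2nc(-c3ccccc3)c(NCc3ccc(F)cc3)nc2c1`, differs from compound 1 in one place: (4-fluorobenzyl)amino in place of 3,4-dichlorophenoxy on an aromatic carbon. The change sits on an aromatic carbon of a six-membered aromatic ring with two nitrogen, part of a fused system of two rings, ortho to a phenyl group. Within the data shown here, no measured pair isolates this kind of exchange, so the step has no direct precedent here; the three measured values all cluster at the weak end, and a step of no more than the usual scatter, if anything toward a lower number, is expected from compound 1 to compound 4.

The estimate for compound 4 is 40000 nM, within 10000 nM to 150000 nM, an expected step of a 1.6-fold lower number from compound 1 to compound 4 (0.21 log units; within the scatter).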

Compound 4, concentration for total growth inhibition: 3800 nM
Beside the measured number, compound 4's estimate is 11-fold (1.02 log units) above it, and the stated range ends above it.
By their numbers in this assay, from the lowest: compound 4; then compounds 3, 2 and 1 (each within the scatter of the next, the first and the last beyond it).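

In this assay, the substituent on this aromatic carbon, next to the ring nitrogen and ortho to a phenyl group, proves able to move the read-out: (4-fluorobenzyl)amino in place of 3,4-dichlorophenoxy gives a 17-fold lower number from compound 1 to compound 4 (1.23 log units; beyond the scatter), a large step beyond the scatter. The earlier compounds shown here showed no such step, since no measured pair among them differed in one place. The two groups match in heavy-atom count, while the entering group carries a hydrogen-bond donor that the leaving group lacks, but nothing available explains the step.

This single exchange alters the linking atoms and the ring substituents together, so the share of each in the step remains unresolved. A 4-fluorophenoxy group or an unsubstituted benzylamino group at this position would separate the two contributions.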